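Adding a methoxy group to compound 2

The compounds below may be only part of what the source reports. "The series", "measured", "known", "first", "only" and "open" are said of these compounds alone.

Compound 2 `O=C(/C=C/c1ccccc1)c1ccc(OCc2ccccc2)cc1` gives 24.3% in a functional assay on HCT-116 cells (Homo sapiens) for antiproliferative activity, read by sulforhodamine B assay, with a stated time of 3 days, tested at 25 uM (a higher number here means a stronger effect of the compound at the concentration tested, a lower number a weaker effect), and stands highest of the two numbers available; the nearest is compound 1 `Cc1ccc(COc2ccc(C(=O)/C=C/c3ccccc3)cc2)cc1`, which in this assay gives 4%. Among the compounds with values here, the only measured step, a number 20.3 percentage points higher from compound 1 to compound 2 (beyond the scatter), is modest and concerns a different part of the molecule. For compound 3 `Cc1ccc(COc2ccc(C(=O)/C=C/c3ccc(F)cc3)cc2)cc1` the entry in this assay reads "not determined" (no result reported), so no number is available for it. Compound 4 `COc1cccc(/C=C/C(=O)c2ccc(OCc3ccccc3)cc2)c1` differs from compound 2 by methoxy in place of hydrogen on an aromatic carbon. Within the data shown here, no measured step touches this part of the structure, so the one known step bears on it only loosely, and the change is expected to move the number little, in either direction. The step of a number 0.7 percentage points higher from compound 2 to compound 4 (within the scatter) is therefore expected to be small. Compound 4 is estimated at 25%, between 5% and 50%.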

Compound 4, a percentage reported as inhibition, at one concentration (the size of the read-out at that concentration, not a potency): 35.4%
Beside the measured number, compound 4's estimate is 10.4 percentage points below it, within the range that was stated.
By their numbers in this assay, from the lowest: compound 1; then compound 2; then compound 4.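

In this assay, the change from phenyl to 3-methoxyphenyl gives a number 11.1 percentage points higher from compound 2 to compound 4 (beyond the scatter) and lifts the read-out beyond the scatter, so this part of the molecule, untouched by the earlier step, does respond to substitution. The size of the step is modest. No measurement available here accounts for the rise.
As far as these compounds go, whether a hydroxyl, an amine or a longer alkoxy chain at this place would go the same way remains open. From the compounds shown here alone, it is equally open whether methoxy would raise the number for compound 1, which carries the methyl group.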